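The compounds below may be only part of what the source reports. "The series", "measured", "known", "first", "only" and "open" are said of these compounds alone.

Measured compounds:
- compound 1 `C=CC(=O)Nc1cc(Nc2ncc(Cl)c(Nc3ccccc3S(=O)(=O)C(C)C)n2)c(OC)cc1N1CCC(N2CCN(C)CC2)CC1`: < 0.3 nM
- compound 2 `C=CC(=O)Nc1cc(Nc2ncc(Cl)c(Nc3ccccc3S(=O)(=O)C(C)C)n2)c(OC)cc1N1CCCCC1`: 29 nM
- compound 3 `C=CC(=O)Nc1cc(Nc2ncc(Cl)c(Nc3ccccc3S(=O)(=O)C(C)C)n2)ccc1N1CCC(N2CCN(C)CC2)CC1`: 4900 nM

In a functional assay on NCI-H3122 cells (Homo sapiens) for inhibition, read by CellTiter-Glo, with a stated time of 72 h (a higher number here means a weaker inhibitor of growth, a lower number a stronger inhibitor of growth), compound 1 stands at the limit of < 0.3 nM in this assay, at which 1 of the 3 values shown sits, which is a limit of the measurement and not a number. So the exact standing of compound 1 is not known; it is only known that it lies at or beyond the limit. Compound 2 and compound 3 sit well away from it: an at least 96-fold higher number from compound 1 to compound 2 (1.98 log units; beyond the scatter) and an at least 16000-fold higher number from compound 1 to compound 3 (4.21 log units; beyond the scatter). Both of those steps take away a whole group from the aromatic ring carrying the acrylamide, and both are large.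

Compound 4 `C=CC(=O)Nc1cc(Nc2ncc(C)c(Nc3ccccc3S(=O)(=O)C(C)C)n2)c(OC)cc1N1CCC(N2CCN(C)CC2)CC1` differs from compound 1 by methyl in place of chloro on an aromatic carbon. This is a different kind of change from the two measured steps: it exchanges one small group for another of the same size on the core, rather than removing a large group. Going by the values given here, neither measured step therefore bears directly on it, and the only guidance is that compound 1 sits at the limit, leaving room below it unseen. A small step is expected, most likely toward a higher number, and possibly not beyond the scatter: an at least 3.3-fold higher number from compound 1 to compound 4 (0.52 log units; beyond the scatter). Compound 4 is estimated at 1 nM, between 0.2 nM and 6 nM.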

Compound 4, concentration for 50% growth inhibition: < 0.3 nM
Compound 4: no number, only a limit; the forecaster's own chance of this, stated with the estimate: 30%; middle value at least 3.3-fold (0.52 log units) from the limit.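

No step can be read between compound 1 and compound 4, because each gives only a limit and not a number: the limit of < 0.3 nM in this assay, at which 2 of the 4 values shown sit. The compounds shown leave open how far apart these two truly lie, and whether methyl in place of chloro on an aromatic carbon changes growth inhibition at all.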